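This account rests on a few compounds, and the source may have more. Where it says the series, first, only, none or still open, it means among the compounds named here.

Measured in an assay on isolated protein for binding affinity to histamine H2 receptor (Homo sapiens); a lower number here means a stronger inhibitor, a higher number a weaker inhibitor:
compound 1 `CCCCCC(=O)c1ccc(OCCCN2CCN(C(=O)C(C)C)CC2)cc1` gives 29500 nM;
compound 2 `CCCCCC(=O)c1ccc(OCCCN2CCN(CC3CC3)CC2)cc1` gives 18600 nM;
compound 3 `CCOC(=O)N1CCN(CCCOc2ccc(C(C)=O)cc2)CC1` gives 39800 nM.

Compound 3 shows the highest number of the three. Its gap to compound 1 lies within the scatter, its gap to compound 2 beyond it. Going by the values given here, the one measured step, a 1.6-fold lower number from compound 1 to compound 2 (0.20 log units; within the scatter), changes the substituent on the amine nitrogen in the ring and stays within the scatter. Compound 4 `CCOC(=O)N1CCN(CCCOc2ccc(C(=O)C3CC3)cc2)CC1` differs from compound 3 by another change: cyclopropyl in place of methyl on a carbonyl carbon. Among the compounds with values here, no measured pair shows this change, so no step bears on it directly; the only step is small. A step in this assay within the scatter is therefore expected: a 1.4-fold lower number from compound 3 to compound 4 (0.15 log units; within the scatter). Compound 4 is expected at about 28000 nM, in the range 12000 nM to 70000 nM.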

Compound 4, inhibition constant: 79400 nM
Compound 4: the middle estimate sits 2.8-fold (0.45 log units) below what was measured; measured number above the stated range.
By their numbers in this assay, from the lowest: compounds 2, 1, 3 and 4 (each within the scatter of the next, the first and the last beyond it).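

In this assay, the first change read on this carbonyl carbon, cyclopropyl in place of methyl, gives a 2.0-fold higher number from compound 3 to compound 4 (0.30 log units; within the scatter), so compound 3 and compound 4 cannot be separated and the larger group brings no lower number. Nothing on hand bears on this result. Open, on these data alone, is whether a phenyl ring or a tert-butyl group on this carbonyl carbon would give a step beyond the scatter. Also open, as far as these compounds go, is whether cyclopropyl here reads the same with the cyclopropylmethyl of compound 2 on the amine nitrogen in the ring.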